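Chloro for methyl on a para position in two settings

This account rests on a few compounds, and the source may have more. Where it says the series, first, only, none or still open, it means among the compounds named here.

Compound 1 `Cc1ccc(NC(=S)N/N=C2\C(=O)Nc3ccc(F)cc32)cc1` gives 8200 nM in a functional assay on L1210 cells (Mus musculus), with a stated time of 48 h; on this read-out higher numbers stand for weaker inhibition and lower numbers for stronger inhibition. Compound 2 `O=C1Nc2ccc(F)cc2/C1=N/NC(=S)Nc1ccc(Cl)cc1` gives 34000 nM. The step of a 4.1-fold higher number from compound 1 to compound 2 (0.62 log units; beyond the scatter) is chloro in place of methyl on an aromatic carbon. Compound 3 `Cc1ccc(CN2C(=O)/C(=N\NC(=S)Nc3ccc(Cl)cc3)c3cc(Cl)ccc32)cc1` gives 9800 nM; the difference between its core and that of compound 1 is not broken down here. Compound 4 `O=C1/C(=N\NC(=S)Nc2ccc(Cl)cc2)c2cc(Cl)ccc2N1Cc1ccc(Cl)cc1` is unmeasured; it differs from compound 3 by chloro in place of methyl on an aromatic carbon, the same kind of change as from compound 1 to compound 2, though here read one bond further out it involves 4-methylbenzyl rather than 4-methylphenyl. The step of a 2.6-fold higher number from compound 3 to compound 4 (0.41 log units; beyond the scatter) is expected to be somewhat smaller than a 4.1-fold higher number from compound 1 to compound 2 (0.62 log units; beyond the scatter), because a 4.1-fold higher number from compound 1 to compound 2 (0.62 log units; beyond the scatter) sits in a different surrounding. Compound 4 is estimated at 25000 nM, between 9000 nM and 70000 nM.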

Compound 4, half-maximal inhibitory concentration: 124000 nM
Compound 4: the middle estimate sits 5.0-fold (0.70 log units) below what was measured, outside the stated range (above it).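

In this assay, chloro in place of methyl gives a higher number on both cores, and a 13-fold higher number from compound 3 to compound 4 (1.10 log units; beyond the scatter) is the larger step, so the two do not match: the same change on two cores in this assay, a 4.1-fold higher number (0.62 log units; beyond the scatter) from compound 1 to compound 2 and a 13-fold higher number (1.10 log units; beyond the scatter) from compound 3 to compound 4, 3.1-fold (0.48 log units) apart, beyond the scatter of two such steps Across these two pairs the direction carries from one core to the other, but the size does not, so a step read on one core does not fix its size on the other. The change sits on 4-methylphenyl in one pair and on 4-methylbenzyl in the other, and the cores also differ elsewhere, so these pairs do not show which difference sets the gap.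

Still open, as far as these compounds go, is whether a methoxy group, an amine or a carboxylic acid at the same place would follow the direction seen with chloro. Two pairs also leave open how the step behaves on any further core.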